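The compounds below may be only part of what the source reports. "The series", "measured", "known", "first", "only" and "open" are said of these compounds alone.

Measured in a functional assay on CAPAN-1 cells (Homo sapiens) for antiproliferative activity, with a stated time of 72 h; a higher number here means a weaker inhibitor, a lower number a stronger inhibitor:
Compound 1 `Nc1ncnn2c([C@@H]3O[C@H](CO)[C@@H](O)[C@H]3O)cc(C#CC3CC3)c12`: 20 nM
Compound 2 `Nc1ncnn2c([C@@H]3O[C@H](CO)[C@@H](O)[C@H]3O)cc(-c3ccc(F)cc3F)c12`: 50900 nM

Compound 2 has the higher of the two numbers. Compound 3 `Cc1ccccc1-c1cc([C@@H]2O[C@H](CO)[C@@H](O)[C@H]2O)n2ncnc(N)c12` differs from it in one place, with 2-methylphenyl in place of 2,4-difluorophenyl on an aromatic carbon. Among the compounds with values here, the one measured step, a 2500-fold higher number from compound 1 to compound 2 (3.41 log units; beyond the scatter), is large, but it exchanges 2-cyclopropylethynyl for 2,4-difluorophenyl, and no measured step exchanges one such phenyl group for another. Compound 3 keeps a six-membered aromatic ring of carbon only at that place, like compound 2 at 50900 nM, so no step beyond the scatter is expected in this assay. The estimated step is a 1.7-fold lower number from compound 2 to compound 3 (0.23 log units; within the scatter). For compound 3 the expected value is 30000 nM, with an estimated range of 5000 nM to 100000 nM.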

Compound 3, half-maximal inhibitory concentration: 97500 nM
Compound 3: middle estimate off by 3.3-fold (0.51 log units), on the low side; measured number inside the range.
By their numbers in this assay, from the lowest: compound 1; then compounds 2 and 3 (each within the scatter of the next).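

In this assay the step of a 1.9-fold higher number from compound 2 to compound 3 (0.28 log units; within the scatter) shows that exchanging 2,4-difluorophenyl for 2-methylphenyl at this aromatic carbon stays within the usual scatter. The step of a 4900-fold higher number from compound 1 to compound 3 (3.69 log units; beyond the scatter) is also large, so a second phenyl group at this place stands as far from 2-cyclopropylethynyl as compound 2 does. Nothing available explains either step. Going by these compounds, it remains open whether a propyl chain, an amine or an unsubstituted ethynyl group at this aromatic carbon would stand with compound 1 or with compound 2 and compound 3.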